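A few compounds are considered here, and "the series" means these few. Any claim that something is new, unique, unknown or untested is made for them only; others in the source may bear on it.

Working notes on the series. Going by the values given here, compound 3 `CC(C)C(c1ccc(-c2ccc3cccc(F)c3c2)[nH]c1=O)N1CCNC1=O` gives 28 nM in a functional assay on CHO cells for antagonist activity at prostaglandin E2 receptor EP3 subtype (Homo sapiens), read by cAMP accumulation (on this read-out higher numbers stand for weaker inhibition and lower numbers for stronger inhibition), the highest of the three numbers measured so far; its nearest neighbour is compound 1 `CC(C)C(c1nnc[nH]1)c1ccc(-c2ccc3cccc(F)c3c2)[nH]c1=O` at 21 nM, its furthest is compound 2 `CC(C)NC(=O)CC(c1ccc(-c2ccc3cccc(F)c3c2)[nH]c1=O)C(C)C` at 15 nM. Both gaps, a 1.3-fold higher number from compound 1 to compound 3 (0.12 log units; within the scatter) and a 1.9-fold higher number from compound 2 to compound 3 (0.27 log units; within the scatter), lie within the scatter, as does a 1.4-fold lower number from compound 1 to compound 2 (0.15 log units; within the scatter), so the three variations at the saturated chain carbon bound to an aromatic carbon and a saturated chain carbon have not separated on this read-out.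

Compound 4 `CC(C)C(Cc1nnn[nH]1)c1ccc(-c2ccc3cccc(F)c3c2)[nH]c1=O` extends the same position: (1H-tetrazol-5-yl)methyl in place of 2-oxoimidazolidin-1-yl on a saturated chain carbon bound to an aromatic carbon and a saturated chain carbon. Among the compounds with values here, no measured step covers this exact exchange; the closest precedents are the swap of 4H-1,2,4-triazol-3-yl for 2-oxoimidazolidin-1-yl in a 1.3-fold higher number from compound 1 to compound 3 (0.12 log units; within the scatter) and the swap of 4H-1,2,4-triazol-3-yl for (isopropylcarbamoyl)methyl in a 1.4-fold lower number from compound 1 to compound 2 (0.15 log units; within the scatter), both within the scatter. The step to compound 4 is therefore expected to be of that kind, a 1.3-fold lower number from compound 3 to compound 4 (0.10 log units; within the scatter), with no direction beyond the scatter. Compound 4 is estimated at 22 nM in this assay, with a range of 8 nM to 60 nM.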

Compound 4, half-maximal inhibitory concentration: 134 nM
Beside the measured number, compound 4's estimate is 6.1-fold (0.78 log units) below it; the whole stated range lies below it.
By their numbers in this assay, from the lowest: compounds 2, 1 and 3 (each within the scatter of the next); then compound 4.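

The position is not indifferent to what it carries on this assay: a 4.8-fold higher number from compound 3 to compound 4 (0.68 log units; beyond the scatter), a 6.4-fold higher number from compound 1 to compound 4 (0.80 log units; beyond the scatter) and an 8.9-fold higher number from compound 2 to compound 4 (0.95 log units; beyond the scatter), each beyond the scatter, set compound 4 apart from the three earlier compounds. An aromatic five-membered ring alone does not go with the higher number, as compound 1 shows, and neither does the extra chain carbon alone, as compound 2 shows; among these compounds, only compound 4 combines the two. Nothing measured here explains the change.

Going by these compounds, it remains open whether the higher number follows the tetrazole ring itself or its link, which 1H-tetrazol-5-yl bound directly to the saturated chain carbon, or carried on a longer chain, would help to separate. On these data alone, it also remains open whether a carboxylic acid in this place would read like compound 4 or like compound 2.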